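This account rests on a few compounds, and the source may have more. Where it says the series, first, only, none or still open, it means among the compounds named here.

Measured in a functional assay on Bel-7402 cells (Homo sapiens) for antiproliferative activity, read by MTT assay, with a stated time of 72 h; on this read-out higher numbers stand for weaker inhibition and lower numbers for stronger inhibition:
- compound 1 `C=C1C(=O)O[C@H]2[C@H]1CC/C(Cn1cc(Cn3cc(F)c(=O)n(Cc4ccccc4)c3=O)nn1)=C\CC[C@@]1(C)O[C@@H]21`: 9160 nM
- compound 2 `C=C1C(=O)O[C@H]2[C@H]1CC/C(COC(=O)CCC(=O)NCCCCCCNC(=O)Cn1cc(F)c(=O)n(Cc3ccccc3)c1=O)=C\CC[C@@]1(C)O[C@@H]21`: 18300 nM
- compound 3 `C=C1C(=O)O[C@H]2[C@H]1CC/C(COC(=O)Cn1cc(F)c(=O)n(Cc3ccc(Br)cc3)c1=O)=C\CC[C@@]1(C)O[C@@H]21`: 2670 nM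

Compound 3 stands at the lowest number of the three. Compound 1 is the nearest to it and sits higher by a margin beyond the scatter; compound 2 is the furthest and sits higher still, also beyond the scatter. Going by the values given here, no pair among the measured compounds differs in only one place, so no single step can be read off between them, and the series gives no direct guide to what removal of the group on the aromatic nitrogen does.

Compound 4 `C=C1C(=O)O[C@H]2[C@H]1CC/C(COC(=O)Cn1cc(F)c(=O)n(C)c1=O)=C\CC[C@@]1(C)O[C@@H]21` is the next case. Its difference from compound 3 is hydrogen in place of 4-bromophenyl on a saturated chain carbon bound to an aromatic nitrogen — the same difference, cut one bond further out, reads 4-bromobenzyl to methyl. Nothing measured here isolates that change. In this assay compound 4 is expected to give 6000 nM, within 2500 nM to 15000 nM. The step of a 2.2-fold higher number from compound 3 to compound 4 (0.35 log units; beyond the scatter) is estimated to run toward a higher number, since compound 3 gives the lowest value of the set at 2670 nM and the other two, which keep a benzyl on that nitrogen, already sit above it; whether the step clears the scatter is uncertain.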

Compound 4, half-maximal inhibitory concentration: 9400 nM
For compound 4 the middle estimate is 1.6-fold (0.19 log units) below the measured one; low and high end bracket the measured number.
By their numbers in this assay, from the lowest: compound 3; then compounds 1, 4 and 2 (each within the scatter of the next).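

In this assay, going by these compounds alone, hydrogen in place of 4-bromophenyl on a saturated chain carbon bound to an aromatic nitrogen gives a 3.5-fold higher number from compound 3 to compound 4 (0.55 log units; beyond the scatter) and is the first change that can be read in one place. The step shows that the group at this position counts toward the number in this assay, since the change lies beyond the scatter, although it is modest and compound 4 still gives a measured value of 9400 nM with only methyl on that nitrogen. No measurement available here speaks to why the number moves.

The step removes the bromine and the aromatic ring together, so it remains open which of them accounts for the difference, and a plain benzyl on the rest of compound 3 would separate the two. Also open, as far as these compounds go, is how a longer chain such as propyl, a 4-methoxybenzyl group or a chain ending in a carboxylic acid would read at this place.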